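The source may report more compounds than this note shows. Statements on the series, on what has been measured and on what is new or still open speak of the compounds shown alone.

In an assay on Sf9 cells for inhibition of protein deacetylase HDAC6 (Homo sapiens), read by fluorescence, with a stated time of 40 min, tested at 100 nM (a lower number here means less inhibition, a higher number more inhibition at the concentration tested (going by the name of the read-out)), compound 1, whose structure is `Cc1ccc(-c2nc(CNc3ccc(C(=O)NO)cc3)n(-c3ccccc3)n2)o1`, gives 60.7%. Among the three compounds measured it stands second highest. Its nearest neighbour is compound 2 (`COc1ccc(-n2nc(-c3ccccc3)nc2CNc2ccc(C(=O)NO)cc2)cc1`), which gives 63.4% in this assay, a figure that sits within the scatter of the value for compound 1. Furthest away is compound 3 (`O=C(O)c1ccc(NCc2nc(-c3ccccc3)nn2-c2ccccc2)cc1`), which gives -0.4% in this assay, a number that lies beyond the scatter below compound 1.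

Compound 4, with the structure `O=C(NO)c1ccc(NCc2nc(-c3ccncc3)nn2-c2ccccc2)cc1`, has not yet been measured. It differs from compound 1 in one place: pyridin-4-yl in place of 5-methylfuran-2-yl on an aromatic carbon. Both compound 1 and compound 2 carry an aromatic group on that carbon and give similar numbers, so a change of one aromatic group for another at this position is expected to move the number little. For the step from compound 1 to compound 4 the expected change is a number 5.7 percentage points lower from compound 1 to compound 4 (within the scatter), that is, none beyond the scatter. For compound 4 the estimated value in this assay is therefore 55%, with a range from 35% to 75%.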

Compound 4, a percentage reported as inhibition, at one concentration (the size of the read-out at that concentration, not a potency): 30.8%
Compound 4: middle estimate off by 24.2 percentage points, on the high side, and the stated range ends above it.
By their numbers in this assay, from the lowest: compound 3; then compound 4; then compounds 1 and 2 (each within the scatter of the next).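

In this assay, putting pyridin-4-yl in place of 5-methylfuran-2-yl on the aromatic carbon gives a number 29.9 percentage points lower from compound 1 to compound 4 (beyond the scatter), so this position does not accept every aromatic group equally. The two groups have the same counts of heavy atoms, hydrogen-bond donors and hydrogen-bond acceptors, so those counts alone do not set the number here; the groups differ in ring size, in the ring hetero atom and in the methyl group. No measurement at hand explains the drop.

The compounds shown do not separate these differences, so it remains open whether the ring size, the ring nitrogen or the methyl group matters most. A comparison with furan-2-yl, which lacks the methyl group, or with pyridin-3-yl at this carbon would help to narrow this down.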